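Working notes: methoxy for chloro on the aryl nitrogen substituent

The compounds below may be only part of what the source reports. "The series", "measured", "known", "first", "only" and "open" are said of these compounds alone.

Compound 2 `Cc1cc2occ(-c3nc(-c4ccccc4)c(-c4ccccc4)n3-c3ccccc3Cl)c(=O)c2cc1Cl` and compound 1 `COc1ccccc1-n1c(-c2coc3cc(C)c(Cl)cc3c2=O)nc(-c2ccccc2)c1-c1ccccc1` share a core and differ by methoxy in place of chloro on an aromatic carbon. In a functional assay on MCF7 cells (Homo sapiens) for inhibition, read by MTT assay, with a stated time of 72 h (on this read-out higher numbers stand for weaker inhibition and lower numbers for stronger inhibition), compound 2 gives 3120 nM, while compound 1 gives 25000 nM; that change made an 8.0-fold higher number from compound 2 to compound 1 (0.90 log units; beyond the scatter). Compound 3 `Cc1cc2occ(-c3nc(-c4ccccc4)c(-c4ccccc4)n3-c3cccc(Cl)c3)c(=O)c2cc1Cl` carries a different aryl group on the ring nitrogen; how its core differs from that of compound 2 is counted as 3-chlorophenyl in place of 2-chlorophenyl on an aromatic nitrogen, and in this assay compound 3 gives 6250 nM, with a 2.0-fold higher number from compound 2 to compound 3 (0.30 log units; within the scatter). Between the two methoxy-free and methoxy-bearing analogues there is also a 4.0-fold lower number from compound 1 to compound 3 (0.60 log units; beyond the scatter). Compound 4 `COc1cccc(-n2c(-c3coc4cc(C)c(Cl)cc4c3=O)nc(-c3ccccc3)c2-c2ccccc2)c1` is not yet measured; it differs from compound 3 by methoxy in place of chloro on an aromatic carbon. This is the same kind of change as from compound 2 to compound 1, but not the same: there the group sat ortho to a large group, here it sits meta to a large group. Only one measured step of this kind exists, and whether its size carries over to the other place is not shown. For compound 4 in this assay the expected step is a 4.0-fold higher number from compound 3 to compound 4 (0.60 log units; beyond the scatter), resting on the size of an 8.0-fold higher number from compound 2 to compound 1 (0.90 log units; beyond the scatter) and widened for the different place. Compound 4 is therefore estimated at 25000 nM, expected within 8000 nM to 80000 nM.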

Compound 4, half-maximal inhibitory concentration: 25000 nM
Estimate against measurement, compound 4: no gap at the digits printed, and the stated range covers the measured number.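

In this assay, methoxy in place of chloro on an aromatic carbon gives a 4.0-fold higher number from compound 3 to compound 4 (0.60 log units; beyond the scatter), in the same direction as the earlier step, and the two sizes cannot be told apart: the same change on two cores in this assay, an 8.0-fold higher number (0.90 log units; beyond the scatter) from compound 2 to compound 1 and a 4.0-fold higher number (0.60 log units; beyond the scatter) from compound 3 to compound 4, 2.0-fold (0.30 log units) apart, within the scatter of two such steps. Exchanging the whole aryl group gives an 8.0-fold higher number from compound 2 to compound 4 (0.90 log units; beyond the scatter), while the two methoxy analogues show no change at the digits printed from compound 1 to compound 4 (within the scatter), so moving the methoxy between these two places leaves no readable difference. The change carried over between these two cores in this one read-out, but a single such pair does not show that it would carry over to a core with the aryl group changed in any other way.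

Still open, on these data alone, is whether the step is specific to methoxy or would also appear with an amine, a carboxylic acid or a longer alkoxy chain in the same place. Also open, as far as these compounds go, is whether the step holds in any cell line or read-out other than this one.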